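A few compounds are considered here, and "the series" means these few. Any claim that something is new, unique, unknown or untested is made for them only; others in the source may bear on it.

- Compound 1 `C[C@H](NC(=O)C1CCOCC1)c1ccc(NC(=O)N2CC(c3cccnc3)C2)cc1`: 17 nM
- Compound 2 `CCC(=O)N[C@@H](C)c1ccc(NC(=O)N2CC(c3cccnc3)C2)cc1`: 25 nM

In a functional assay on A2780 cells (Homo sapiens) for antiproliferative activity, read by CellTiter-Glo, with a stated time of 72 h (a higher number here means a weaker inhibitor, a lower number a stronger inhibitor), compound 1 gives 17 nM, level within the scatter with compound 2 at 25 nM. Compound 3 `C[C@H](NC(=O)C1CCOCC1)c1ccc(NC(=O)N2CC(c3ccc(N)nc3)C2)cc1` keeps the rest of compound 1 and changes pyridin-3-yl to 6-aminopyridin-3-yl: amino in place of hydrogen on an aromatic carbon. Among the measured compounds shown here, the only measured step, a 1.5-fold higher number from compound 1 to compound 2 (0.17 log units; within the scatter), lies within the scatter and swaps a different group, so no measured step bears directly on this change. With so little to go on, no clear shift is expected, only a wide uncertainty. The expected step is a 1.8-fold higher number from compound 1 to compound 3 (0.25 log units; within the scatter). For compound 3 the estimated value is 30 nM, with an expected range of 6 nM to 200 nM.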

Compound 3, half-maximal inhibitory concentration: 46 nM
Beside the measured number, compound 3's estimate is 1.5-fold (0.19 log units) below it; low and high end bracket the measured number.
By their numbers in this assay, from the lowest: compounds 1, 2 and 3 (each within the scatter of the next, the first and the last beyond it).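

The pyridine ring now has a measured change of its own: the earlier pair differed only in the group on the carbonyl carbon. In this assay, placing amino next to the ring nitrogen and para to a large group gives a 2.7-fold higher number from compound 1 to compound 3 (0.43 log units; beyond the scatter), a modest but real loss that stands beyond the scatter. Nothing available explains this loss. On these data alone, whether methoxy or fluorine on that same carbon would do better remains open, as does whether amino would have a similar effect on compound 2.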